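The source may report more compounds than this note shows. Statements on the series, on what has been measured and on what is new or still open speak of the compounds shown alone.

Among the measured compounds shown here, compound 2 `Cc1ccc2c(N=[N+]=[N-])c(Cc3ccccc3)cnc2n1` gives the only number in this set: in an assay for binding affinity to adenosine receptor A1 (Bos taurus) (a lower number here means a stronger inhibitor, a higher number a weaker inhibitor), compound 2 gives 3340 nM. Compound 1 `Cc1ccc2c(O)c(Cc3ccccc3)cnc2n1` reaches only a limit in this assay, where compound 1 gives > 10000 nM. For the measured compounds named here, the single measured step, an at least 2.9-fold lower number from compound 1 to compound 2 (0.47 log units; beyond the scatter), runs from that limit to the number of compound 2, and its true size is bounded by the limit of > 10000 nM in this assay, at which 1 of the 2 values shown sits. Compound 3 `Cc1ccc2c(NN)c(Cc3ccccc3)cnc2n1` differs from compound 2 by aminoamino in place of azido on an aromatic carbon. Compound 3 thus carries hydrogen-bond donors once more, as compound 1 does, while compound 2 has none in that group. Going by the values given here, since the only step that bears on this change, an at least 2.9-fold lower number from compound 1 to compound 2 (0.47 log units; beyond the scatter), lowered the number when azido replaced hydroxy, removing the azido group in favour of aminoamino is expected to raise the number in this assay, by an estimated 2.4-fold higher number from compound 2 to compound 3 (0.38 log units; beyond the scatter). Compound 3 is therefore estimated at 8000 nM, within a range of 2500 nM to 25000 nM, with a real chance that only a limit is reported.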

Compound 3, inhibition constant: 220 nM
The estimate for compound 3 lay 36-fold (1.56 log units) above the measured number; the whole stated range lies above it.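

The position opposite the ring nitrogen responds strongly to the group placed on it: in this assay, aminoamino in place of azido gives a 15-fold lower number from compound 2 to compound 3 (1.18 log units; beyond the scatter), reversing the direction that the earlier step alone had suggested. Hydrogen-bond donors in this group therefore do not go with a weak result by themselves, since compound 1 and compound 3 both carry them and yet the change from hydroxy to aminoamino gives an at least 45-fold lower number from compound 1 to compound 3 (1.65 log units; beyond the scatter). On these data alone, the true size of that step remains open, and it can be read only as a bound: the limit of > 10000 nM in this assay, at which 1 of the 3 values shown sits.

The compounds shown leave open whether a plain amine or a methylamino group at this position would match aminoamino. They also leave open whether a methyl group on the outer nitrogen of aminoamino would be tolerated in this assay.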